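Swapping the Amide Ring on Compound 3

The source may hold more compounds than are shown below. What is called first, only, known or untested is meant among the compounds shown, and "the series" means these compounds.

In a functional assay on A549 cells (Homo sapiens) for antiproliferative activity, read by MTT assay, with a stated time of 72 h (a higher number here means a weaker inhibitor, a lower number a stronger inhibitor), compound 3 (`COc1cc(N(C)CCN(C)C)c(NC(=O)c2ccncc2OC)cc1Nc1nccc(-c2cn(C)c3ccccc23)n1`) gives 2690 nM, within the scatter of compound 1 (`COc1cc(F)c(NC(=O)c2cnccn2)cc1Nc1nccc(-c2cn(C)c3ccccc23)n1`) at 2490 nM. Compound 2 (`COc1cc(N(C)CCN(C)C)c(NC(=O)c2ccnc(O)c2)cc1Nc1nccc(-c2cn(C)c3ccccc23)n1`) gives 11200 nM, and the series shows a 4.2-fold lower number from compound 2 to compound 3 (0.62 log units; beyond the scatter), a modest step beyond the scatter.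

Compound 4 (`COc1cc(N(C)CCN(C)C)c(NC(=O)c2cnccn2)cc1Nc1nccc(-c2cn(C)c3ccccc23)n1`) is the next case. It has pyrazin-2-yl in place of 3-methoxypyridin-4-yl on a carbonyl carbon. Compound 1 carries the same pyrazin-2-yl on its carbonyl carbon, although its core differs from that of compound 3.

Within the data shown here, only one measured step bears directly on this place, a 4.2-fold lower number from compound 2 to compound 3 (0.62 log units; beyond the scatter), and it shows that a change here can matter in this assay. It gives no direction for this new replacement. Compound 1 at 2490 nM offers no sign of a large move, so no shift beyond the scatter is expected, and the expected step is a 1.1-fold lower number from compound 3 to compound 4 (0.03 log units; within the scatter). For compound 4 the estimated value is 2500 nM, with an expected range from 900 nM to 7000 nM.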

Compound 4, half-maximal inhibitory concentration: 4330 nM
The estimate for compound 4 lay 1.7-fold (0.24 log units) below the measured number; the measured number falls inside the stated range.
By their numbers in this assay, from the lowest: compounds 1, 3 and 4 (each within the scatter of the next); then compound 2.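

In this assay, the step of a 1.6-fold higher number from compound 3 to compound 4 (0.21 log units; within the scatter) shows that pyrazin-2-yl and 3-methoxypyridin-4-yl on this carbonyl carbon cannot be told apart, even though the two rings differ in their hetero atoms. Against 2-hydroxypyridin-4-yl the result is different: a 2.6-fold lower number from compound 2 to compound 4 (0.41 log units; beyond the scatter) means that compound 2 now stands apart from both compound 3 and compound 4 at this place. With pyrazin-2-yl held fixed, the other change, (2-(dimethylamino)ethyl)(methyl)amino in place of fluoro on an aromatic carbon, gives a 1.7-fold higher number from compound 1 to compound 4 (0.24 log units; within the scatter), so that exchange also stays within the scatter.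

Nothing available explains why compound 2 differs from the others at this place. On these data alone, whether a saturated ring such as piperidin-4-yl, or a pyridine ring bearing a carboxylic acid, on this carbonyl carbon would move the number beyond the scatter remains open.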